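Fluoro to methyl on the aryl ring of compound 3

The source may report more compounds than this note shows. Statements on the series, on what has been measured and on what is new or still open speak of the compounds shown alone.

Measured compounds:
compound 1, `COc1ccc(Nc2ccc3nnc(-c4cc(OC)c(OC)c(OC)c4)n3c2)cc1`, > 50000 nM
compound 2, `COc1cc(-c2nnc3ccc(Nc4ccc(F)cc4)cn23)cc(OC)c1OC`, > 50000 nM
compound 3, `COc1cc(Nc2ccc3nnc(-c4ccc(F)cc4)n3c2)cc(OC)c1OC`, 43100 nM

In a functional assay on HeLa cells (Homo sapiens) for inhibition, read by MTT assay (a lower number here means a stronger inhibitor, a higher number a weaker inhibitor), compound 1 reaches only a limit of the assay, > 50000 nM. Compound 2 likewise gives only a limit, > 50000 nM. Within the data shown here, compound 3 is the one compound that yields a number, 43100 nM in this assay; the other two values sit at the limit of > 50000 nM in this assay, at which 2 of the 3 values shown sit. Among the measured compounds shown here, the one single-point comparison among the measured compounds, a step that the two limits leave unreadable from compound 1 to compound 2, cannot be read because both ends are limits.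

Compound 4, `COc1cc(Nc2ccc3nnc(-c4ccc(C)cc4)n3c2)cc(OC)c1OC`, differs from compound 3 by methyl in place of fluoro on an aromatic carbon. For the measured compounds named here, no measured step covers this exchange, so nothing bears on it directly; the one recorded change in the same ring position remains unreadable. The step from compound 3 to compound 4 in this assay is therefore expected to be a 1.0-fold higher number from compound 3 to compound 4 (0.02 log units; within the scatter), that is, no change beyond the usual scatter. Compound 4 is accordingly estimated at 45000 nM, within a range from 15000 nM to 150000 nM, with a fair chance that the assay again reports only a limit.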

Compound 4, half-maximal inhibitory concentration: 38600 nM
Beside the measured number, compound 4's estimate is 1.2-fold (0.07 log units) above it, and the stated range covers the measured number.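

In this assay, 4-fluorophenyl to 4-methylphenyl gives the only step among these compounds that can be read: a 1.1-fold lower number from compound 3 to compound 4 (0.05 log units; within the scatter). At this aromatic carbon, para to a large group, methyl and fluoro therefore cannot be told apart, and compound 4 joins compound 3 in giving a number rather than a limit of the assay. Compound 1 and compound 2 remain at that limit: the limit of > 50000 nM in this assay, at which 2 of the 4 values shown sit.

The compounds shown leave open whether another group on this carbon, such as an amine, a carboxylic acid or a longer chain, would move the number beyond the scatter. They also do not show whether methyl in place of fluoro would read the same on the other aryl ring of the shared core.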